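Swapping a Phenyl for an Allyl on a Ring Nitrogen

The compounds below may be only part of what the source reports. "The series", "measured", "known", "first", "only" and "open" are said of these compounds alone.

Two compounds of this series have so far been run in a functional assay on the whole organism (strain albino) for inhibition, with Rattus norvegicus as the target, read by paw edema, with a stated time of 1 h, at a dose of 0.28 mmol/kg by the oral route; on this read-out lower numbers stand for less inhibition and higher numbers for more inhibition at the one dose given (going by the name of the read-out). Compound 1 `C=CCn1c(SC/C(=N\O)c2ccccc2)nnc1-c1ccc(OC)c(OC)c1` gives 53% in this assay, and compound 2 `COc1ccc(-c2nnc(SCC(=O)c3ccccc3)n2-c2ccccc2)cc1OC` gives 56%. Compound 2 holds the higher of the two numbers, yet compound 1 sits within the scatter of it, so the two values show no real separation. Compound 3 `C=CCn1c(SCC(=O)c2ccccc2)nnc1-c1ccc(OC)c(OC)c1` is the next member to be measured. It differs from compound 2 in one place only: allyl in place of phenyl on an aromatic nitrogen. Among the measured compounds shown here, no pair of measured compounds covers this change on its own, so the size of its effect is unknown. Compound 3 is expected to show a step of a number 1 percentage points lower from compound 2 to compound 3 (within the scatter) that stays within the scatter, in neither direction, because compound 1 with 53% already lies close to compound 2. Compound 3 is therefore estimated at 55%, with a range from 43% to 67%.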

Compound 3, a percentage reported as inhibition, in the whole organism at one dose (the size of the read-out at that dose, not a potency): 61%
The estimate for compound 3 lay 6 percentage points below the measured number, and the stated range covers the measured number.
By their numbers in this assay, from the lowest: compounds 1, 2 and 3 (each within the scatter of the next).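

In this assay, among the compounds shown here, allyl in place of phenyl on the aromatic nitrogen gives a number 5 percentage points higher from compound 2 to compound 3 (within the scatter), the first direct reading of this change: a group of 3 heavy atoms with no ring replaces one of 6 with a ring, and the read-out stays within the scatter. The other new step, a group of 8 heavy atoms in place of one of 9 on the saturated chain carbon bound to the sulfur, gives a number 8 percentage points higher from compound 1 to compound 3 (within the scatter), so this second change also shows no separation. No measurement bears on what lies behind either step.

Going by these compounds, whether a saturated propyl group, a plain methyl or a chain ending in an amine on this ring nitrogen would move the read-out beyond the scatter remains open. So does the effect of a carboxylic acid in place of the benzoyl part of the (benzoylmethyl)sulfanyl group.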